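The compounds below may be only part of what the source reports. "The series", "measured", "known", "first", "only" and "open" are said of these compounds alone.

Compound 1 `O=C(c1cc(-c2cn[nH]c2)on1)N1CCC(Cc2ccccc2)CC1` gives 71.6 mL/min/kg
Compound 2 `O=C(c1cc(-c2ccc(=O)[nH]c2)on1)N1CCC(Cc2ccc(Cl)cc2)CC1` gives 5.4 mL/min/kg
Compound 3 `O=C(Nc1ccc2[nH]c(=O)oc2c1)C(=O)N1CCN(c2ccc(C(F)(F)F)cc2)CC1` gives 15.1 mL/min/kg

These three numbers come from an ADME assay on the whole organism (Rattus norvegicus, strain Sprague-Dawley) for pharmacokinetics, using cassette dosing, at a dose of 0.5 mg/kg by the intravenous route; on this read-out lower numbers stand for slow clearance and higher numbers for fast clearance. Compound 3, at 15.1 mL/min/kg, is the second highest of the three. Compound 2, at 5.4 mL/min/kg, gives a lower number than compound 3, and compound 1, at 71.6 mL/min/kg, gives a higher number than compound 3. Both gaps lie beyond the usual scatter.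

The next compound to be measured is compound 4 `O=C(Nc1ccc2[nH]c(=O)oc2c1)C(=O)N1CCN(c2ccc(Cl)c(F)c2)CC1`. It differs from compound 3 in one place, with 4-chloro-3-fluorophenyl in place of 4-(trifluoromethyl)phenyl on an amine nitrogen in a ring. Among the compounds with values here, no two measured compounds differ in only one place, so the data offer no measured step against which to judge this change. Compounds 1 and 2 share little with compound 4, and the expectation therefore rests on compound 3 at 15.1 mL/min/kg alone. The step expected in this assay is a 1.0-fold lower number from compound 3 to compound 4 (0.00 log units; within the scatter), which is estimated to stay within the usual scatter, with neither direction favoured. For compound 4 the estimated clearance is 15 mL/min/kg, with an expected range from 6 mL/min/kg to 36 mL/min/kg.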

Compound 4, clearance: 5.6 mL/min/kg
For compound 4 the middle estimate is 2.7-fold (0.43 log units) above the measured one; measured number below the stated range.
By their numbers in this assay, from the lowest: compounds 2 and 4 (each within the scatter of the next); then compound 3; then compound 1.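

Within the data shown here, this is the first comparison that differs in one place only. On the amine nitrogen of the six-membered non-aromatic ring with 2 nitrogen, 4-chloro-3-fluorophenyl in place of 4-(trifluoromethyl)phenyl gives a 2.7-fold lower number from compound 3 to compound 4 (0.43 log units; beyond the scatter) in this assay and thus shows that, with the rest of the compound held fixed, the aryl group at this place bears on the read-out. The change swaps the whole substituent pattern at once, so this single step cannot assign the shift to the chlorine, to the fluorine or to the loss of the trifluoromethyl group. Nothing available here explains why the number moves in this direction.

As far as these compounds go, it remains open how a 4-chlorophenyl, a 3-fluorophenyl, an unsubstituted phenyl or a pyridine ring on the same nitrogen would read, and so which part of the 4-chloro-3-fluorophenyl group goes with the lower number. From the compounds shown here alone, it also remains open whether the same swap would give a step of similar size on a different core, such as that of compound 1 or compound 2.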